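A Thiophene Ring Steps In for Fluorophenyl

The source may report more compounds than this note shows. Statements on the series, on what has been measured and on what is new or still open speak of the compounds shown alone.

Of the compounds shown here, three sharing one core have been measured. Compound 1 `NNC(=O)CSc1nnc(-c2ccncc2)o1` gives 3260 nM in a functional assay on BGC-823 cells (Homo sapiens) for cytotoxicity, read by MTT assay, with a stated time of 48 h; a higher number here means a weaker inhibitor, a lower number a stronger inhibitor. Compound 2 `O=C(CSc1nnc(-c2ccncc2)o1)N/N=C/c1ccc(F)cc1` gives 17800 nM, the highest of the three numbers and so the weakest inhibitor among them. Compound 3 `COc1cc(/C=N/NC(=O)CSc2nnc(-c3ccncc3)o2)ccc1O` gives 4320 nM. Within the data shown here, the only single-point change measured so far is a 4.1-fold lower number from compound 2 to compound 3 (0.61 log units; beyond the scatter), where a 4-hydroxy-3-methoxyphenyl stood in place of 4-fluorophenyl on a carbon with a double bond to nitrogen.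

Compound 4 `O=C(CSc1nnc(-c2ccncc2)o1)N/N=C/c1cccs1` is the next one to be tested. Compared with compound 2 the change is thiophen-2-yl in place of 4-fluorophenyl on a carbon with a double bond to nitrogen. Among the measured compounds shown here, this is the same kind of swap as the one measured step: a different aromatic group on the same carbon. That step lowered the number modestly, which suggests that altering this group can matter, though a five-membered ring with one sulfur is not the same as the phenol tested before, so the direction is uncertain. The expectation for compound 4 is therefore a modest drop from compound 2, written as a 2.0-fold lower number from compound 2 to compound 4 (0.30 log units; within the scatter). Compound 4 is estimated at 9000 nM, within a range from 3500 nM to 23000 nM.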

Compound 4, half-maximal inhibitory concentration: 26700 nM
Compound 4: middle estimate off by 3.0-fold (0.47 log units), on the low side; the measured number lies above the stated range.
By their numbers in this assay, from the lowest: compounds 1 and 3 (each within the scatter of the next); then compounds 2 and 4 (each within the scatter of the next).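

On a carbon with a double bond to nitrogen, swapping 4-fluorophenyl for thiophen-2-yl gives no readable change in this assay, with a 1.5-fold higher number from compound 2 to compound 4 (0.18 log units; within the scatter), so this five-membered ring with its sulfur and the larger fluorinated ring cannot be told apart here. The choice of group at this place still matters, as a 6.2-fold higher number from compound 3 to compound 4 (0.79 log units; beyond the scatter) shows: the gain seen earlier belongs to 4-hydroxy-3-methoxyphenyl and does not come from simply exchanging one aromatic group for another. Compound 1, which has no aromatic group at this end, also differs clearly from the thiophene compound, with an 8.2-fold higher number from compound 1 to compound 4 (0.91 log units; beyond the scatter), so adding thiophen-2-yl and its linking atoms to the shared core brings no gain in this cell assay.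

No evidence is available to explain why these groups behave as they do. Going by these compounds, it also remains open whether the hydroxy or the methoxy group accounts for the lower number of compound 3, and how an amine or a carboxylic acid on the aromatic ring would read in this assay.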